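Hydrazide series on the shared core: phenyl for hydrogen at the carbonyl

The compounds below may be only part of what the source reports. "The series", "measured", "known", "first", "only" and "open" are said of these compounds alone.

Compound 1 `COc1ccc(C(=O)NNC(=O)c2ccc3[nH]c(-c4ccc([N+](=O)[O-])o4)nc3c2)cc1OC` carries a 3,4-dimethoxyphenyl on the hydrazide carbonyl carbon; in a functional assay on DU-145 cells (Homo sapiens) for inhibition, read by sulforhodamine B assay, with a stated time of 48 h (on this read-out lower numbers stand for stronger inhibition of growth and higher numbers for weaker inhibition of growth), compound 1 gives 15.6 ug/mL. Compound 2 `O=CNNC(=O)c1ccc2[nH]c(-c3ccc([N+](=O)[O-])o3)nc2c1` has hydrogen in place of 3,4-dimethoxyphenyl on that carbonyl carbon, and in this assay compound 2 gives 15.6 ug/mL. The step of no change at the digits printed from compound 1 to compound 2 (within the scatter) is thus flat, and compound 2 stands level with compound 1 at the digits shown, within the scatter.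

Compound 3 `O=C(NNC(=O)c1ccc2[nH]c(-c3ccc([N+](=O)[O-])o3)nc2c1)c1ccccc1` is the next point in the same place: phenyl in place of hydrogen on a carbonyl carbon, the formyl becoming a benzoyl. Within the data shown here, the only measured step that bears on it is the removal of an aryl group from this carbonyl carbon, which moved nothing; adding a plain phenyl back is expected to move nothing beyond the scatter either, giving no change at the digits printed from compound 2 to compound 3 (within the scatter). For compound 3 the expected value in this assay is therefore 15.6 ug/mL, with a range of 7.8 ug/mL to 31 ug/mL.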

Compound 3, concentration for 50% growth inhibition: 15.6 ug/mL
Estimate against measurement, compound 3: no gap at the digits printed; low and high end bracket the measured number.
By their numbers in this assay, from the lowest: compounds 1, 2 and 3 (each within the scatter of the next).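

In this assay the step of no change at the digits printed from compound 2 to compound 3 (within the scatter) shows that a phenyl ring with no substituents reads the same as hydrogen on this carbonyl carbon. The step of no change at the digits printed from compound 1 to compound 3 (within the scatter) separates the two methoxy groups from the ring itself, which the earlier pair changed together, and neither part on its own shifts the read-out across these three compounds. No data are available to explain why this position stays flat.

The compounds shown leave open whether an aminomethyl group, a carboxylic acid or a longer alkyl chain on this carbonyl carbon would also read level with hydrogen and phenyl. They also leave open whether any change away from this carbonyl carbon, such as replacing the nitro group on the shared core, would move the value.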